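This account rests on a few compounds, and the source may have more. Where it says the series, first, only, none or still open, it means among the compounds named here.

Measured in a functional assay on NCI-H226 cells (Homo sapiens) for antiproliferative activity, read by sulforhodamine B assay, with a stated time of 48 h; a higher number here means a weaker inhibitor, a lower number a stronger inhibitor:
- compound 1 `O=C(NCCCNc1cc(-c2cn(-c3ccccc3)nc2-c2cccc(O)c2)ccn1)Nc1ccc(F)cc1`: 3390 nM
- compound 2 `O=C(NCCCNc1cc(-c2cn(-c3ccccc3)nc2-c2cccc(O)c2)ccn1)Nc1cccc(C(F)(F)F)c1`: 4880 nM

Among the compounds with values here, compound 1 cannot be separated from compound 2, its only neighbour on these numbers: a 1.4-fold higher number from compound 1 to compound 2 (0.16 log units; within the scatter). Compound 3 `COc1cccc(-c2nn(-c3ccccc3)cc2-c2ccnc(NCCCNC(=O)Nc3ccc(F)cc3)c2)c1` keeps the rest of compound 1 and turns its 3-hydroxyphenyl into 3-methoxyphenyl: methyl in place of hydrogen on an oxygen on an aromatic ring. Within the data shown here, no measured step touches this oxygen. Among the measured compounds shown here, the one available step, to compound 2, changes a different place and stays small, so it offers no direction and only a weak hint about size. A modest change, not clearly beyond the scatter, is therefore expected in this assay: a 1.2-fold higher number from compound 1 to compound 3 (0.07 log units; within the scatter). For compound 3 the estimated value is 4000 nM, with an expected range from 1400 nM to 12000 nM.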

Compound 3, half-maximal inhibitory concentration: 10800 nM
For compound 3 the middle estimate is 2.7-fold (0.43 log units) below the measured one, within the range that was stated.
By their numbers in this assay, from the lowest: compounds 1 and 2 (each within the scatter of the next); then compound 3.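

In this assay, replacing hydroxy with methoxy on the 3-hydroxyphenyl gives a 3.2-fold higher number from compound 1 to compound 3 (0.50 log units; beyond the scatter). This position therefore responds to the addition of a single methyl, whereas the change at the other end of the molecule, a 1.4-fold higher number from compound 1 to compound 2 (0.16 log units; within the scatter), could not be told apart from noise. Nothing measured here explains why the weaker result appears at this oxygen.

As far as these compounds go, it remains open whether the loss comes from the added methyl or from the missing hydrogen, and what an amine or an ethoxy group would do in this place.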